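Amide aryl swap on the core of compound 1

The compounds below may be only part of what the source reports. "The series", "measured", "known", "first", "only" and "open" are said of these compounds alone.

Compound 1 `CCc1ccc(NC(=O)c2cccc(/C=C3\CC(=O)N(c4ccccc4)C3=O)c2)cc1` gives, in an ADME assay on SW480 cells (Homo sapiens) for cytotoxicity, read by MTT assay, with a stated time of 72 h (on this read-out higher numbers stand for weaker inhibition and lower numbers for stronger inhibition), only a limit of the assay, > 100000 nM. Going by the values given here, compound 2 `CCc1cccc(NC(=O)c2cccc(/C=C3\CC(=O)N(Cc4ccccc4)C3=O)c2)c1` reads 91500 nM in this assay, and compound 3 `CCCCCN1C(=O)C/C(=C\c2cccc(C(=O)Nc3cccc(CC)c3)c2)C1=O` reads 83300 nM; the one measured step between them, a 1.1-fold lower number from compound 2 to compound 3 (0.04 log units; within the scatter), is within the scatter. Compound 1 sits at the limit (the limit of > 100000 nM in this assay, at which 1 of the 3 values shown sits), so its place among the three is known only as a range. Compound 4 `O=C(Nc1cccc(F)c1)c1cccc(/C=C2\CC(=O)N(c3ccccc3)C2=O)c1` differs from compound 1 in one place: 3-fluorophenyl in place of 4-ethylphenyl on an amide-type nitrogen. Among the compounds with values here, no measured step covers this change, and nothing among the three values points to a shift beyond the scatter. The estimated step is therefore an at least 1.0-fold lower number from compound 1 to compound 4 (0.02 log units; that floor lies within the scatter), with no movement beyond the scatter expected. Compound 4 is expected at 95000 nM, in a range of 45000 nM to 200000 nM, a limit being about as likely as a number.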

Compound 4, half-maximal inhibitory concentration: > 100000 nM
Compound 4: only a limit was reported; the forecaster's own chance of this, stated with the estimate: 55%; at least 1.0-fold (0.02 log units) between middle value and limit.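

Compound 1 and compound 4 both sit at a limit of the assay, so no step between them can be read: the limit of > 100000 nM in this assay, at which 2 of the 4 values shown sit.

From the compounds shown here alone, how 3-fluorophenyl and 4-ethylphenyl on an amide-type nitrogen compare in this assay stays open.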